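Nitro to fluoro on the aniline of compound 2

This account rests on a few compounds, and the source may have more. Where it says the series, first, only, none or still open, it means among the compounds named here.

Working notes on the series. Of the compounds shown here, two have been measured in a functional assay on MCF7 cells (Homo sapiens) for antiproliferative activity, read by MTT assay, with a stated time of 48 h; a lower number here means a stronger inhibitor, a higher number a weaker inhibitor. Compound 1 `Cc1ccc2nc(Nc3ccnc(Nc4ccc(S(C)(=O)=O)cc4)n3)sc2c1` gives > 50000 nM, which is a limit of the assay and not a number. Compound 2 `Cc1cnc(Nc2ccc([N+](=O)[O-])cc2)nc1Nc1nc2ccccc2s1` likewise gives > 50000 nM, again a limit rather than a number. Among the compounds with values here, compound 2 thus stands at the limit of > 50000 nM in this assay, at which 2 of the 2 values shown sit, so both measured compounds sit at the same limit and no step between them can be read, nor any ordering of the two.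

Compound 3 `Cc1cnc(Nc2ccc(F)cc2)nc1Nc1nc2ccccc2s1` is yet to be measured in this assay. It differs from compound 2 in one place: fluoro in place of nitro on an aromatic carbon. Within the data shown here, no measured step gives a scale for such a change, and nothing measured speaks for either direction. The expected step is an at least 1.2-fold lower number from compound 2 to compound 3 (0.09 log units; that floor lies within the scatter), with no change beyond the scatter foreseen. Compound 3 is accordingly estimated at 40000 nM, with a range from 8000 nM to 100000 nM, and a limit rather than a number is considered the likelier outcome.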

Compound 3, half-maximal inhibitory concentration: > 50000 nM
Compound 3 gave a limit, no number; the forecaster's own chance of this, stated with the estimate: 70%; at least 1.2-fold (0.09 log units) between middle value and limit.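

Within the data shown here, compound 2 and compound 3 both end at a limit of the assay rather than a number, so no step from nitro to fluoro can be read between them. The compounds shown leave open whether any group at this place gives a measurable value in this assay.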